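Hydroxymethyl on the Benzyl Group: Expected Tolerance

The source may hold more compounds than are shown below. What is called first, only, known or untested is meant among the compounds shown, and "the series" means these compounds.

Compound 3 `Cc1ccc(CC2(C)CC(S(=O)(=O)c3ccc(F)cc3)=C(c3ccc(/C(N)=N/O)cc3)O2)cc1` has the lowest of three numbers in an ADME assay on cells (Peritoneal macrophage, Mus musculus, strain Balb/c) for cytotoxicity, read by resazurin assay, with a stated time of 72 h (a higher number here means that more compound is tolerated, a lower number that less compound is tolerated), at 54400 nM, yet its steps to the other two stay within the scatter: a 1.9-fold lower number from compound 1 to compound 3 (0.27 log units; within the scatter) and a 1.7-fold lower number from compound 2 to compound 3 (0.23 log units; within the scatter). Compound 1 `CC1(Cc2ccccc2)CC(S(=O)(=O)c2ccc(F)cc2)=C(c2ccc(/C(N)=N/O)cc2)O1` gives 102000 nM in this assay and compound 2 `COc1cc(CC2(C)CC(S(=O)(=O)c3ccc(F)cc3)=C(c3ccc(/C(N)=N/O)cc3)O2)cc(OC)c1OC` gives 92300 nM; a 1.1-fold lower number from compound 1 to compound 2 (0.04 log units; within the scatter). Compound 4 `CC1(Cc2ccc(CO)cc2)CC(S(=O)(=O)c2ccc(F)cc2)=C(c2ccc(/C(N)=N/O)cc2)O1` differs from compound 3 by hydroxy in place of hydrogen on a saturated chain carbon bound to an aromatic carbon. Going by the values given here, the steps that bear on this are the ones varying the same benzyl group, and none moved beyond the scatter. Compound 4 is therefore expected to show no step beyond the scatter in this assay, with a 1.2-fold higher number from compound 3 to compound 4 (0.08 log units; within the scatter). The estimate for compound 4 is 65000 nM, between 28000 nM and 150000 nM.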

Compound 4, half-maximal cytotoxic concentration: > 100000 nM
Compound 4 was reported as a limit; the forecaster's own chance of this, stated with the estimate: 10%; at least 1.5-fold (0.18 log units) between middle value and limit.
By their numbers in this assay, from the lowest: compounds 3, 2 and 1 (each within the scatter of the next).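

Compound 4, carrying 4-(hydroxymethyl)benzyl in place of 4-methylbenzyl, is recorded in this assay as a limit and not as a number: the limit of > 100000 nM in this assay, at which 1 of the 4 values shown sits. The readable steps are an at least 1.8-fold higher number from compound 3 to compound 4 (0.26 log units; that floor lies within the scatter) and an at least 1.0-fold higher number from compound 2 to compound 4 (0.03 log units; that floor lies within the scatter), both floors within the scatter, while the step involving compound 1 cannot be read. Hydroxy at this place therefore gives no sign of lower tolerance, but the size of its step remains unknown. On these data alone, it remains open how far compound 4 lies past its limit, and whether an amine or a carboxylic acid on this saturated chain carbon would give a step beyond the scatter.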